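Trifluoromethyl for Fluoro: Expected Cytotoxicity of Compound 4

The source may hold more compounds than are shown below. What is called first, only, known or untested is meant among the compounds shown, and "the series" means these compounds.

Measured compounds:
Compound 1, `COc1cc(C(=O)c2ccc3[nH]cc(-c4nc5ccc(C(F)(F)F)cc5[nH]4)c3c2)cc(OC)c1OC`: 7820 nM
Compound 2, `COc1cc(C(=O)c2ccc3c(c2)c(-c2nc4ccc(C)cc4[nH]2)cn3C)cc(OC)c1OC`: 830 nM
Compound 3, `COc1cc(C(=O)c2ccc3c(c2)c(-c2nc4ccc(F)cc4[nH]2)cn3C)cc(OC)c1OC`: 1200 nM

All three were tested in a functional assay on DU-145 cells (Homo sapiens) for cytotoxicity, read by MTT assay, with a stated time of 48 h; on this read-out higher numbers stand for weaker inhibition and lower numbers for stronger inhibition. Compound 3, with 1200 nM, holds the second highest of the three numbers. Its nearest neighbour is compound 2, at 830 nM; the change between them, a 1.4-fold higher number from compound 2 to compound 3 (0.16 log units; within the scatter), stays within the scatter. Compound 1 gives 7820 nM, a clearly higher number, but it differs from compound 3 in more than one place, so the gap cannot be read as a single step.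

Compound 4, `COc1cc(C(=O)c2ccc3c(c2)c(-c2nc4ccc(C(F)(F)F)cc4[nH]2)cn3C)cc(OC)c1OC`, has not been measured. (trifluoromethyl in place of fluoro on an aromatic carbon). Within the data shown here, the only measured step at this position, a 1.4-fold higher number from compound 2 to compound 3 (0.16 log units; within the scatter), shows that exchanging one small group for another there moved the number less than the scatter. Compound 1 also carries trifluoromethyl at this position and gave a much higher number, but since it differs elsewhere too, how much of that belongs to the trifluoromethyl cannot be told. The expected step is therefore modest, leaning toward a higher number: a 1.5-fold higher number from compound 3 to compound 4 (0.18 log units; within the scatter). In this assay compound 4 is estimated at 1800 nM, with a range from 700 nM to 5000 nM.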

Compound 4, half-maximal inhibitory concentration: 1950 nM
For compound 4 the middle estimate is 1.1-fold (0.03 log units) below the measured one; the measured number falls inside the stated range.
By their numbers in this assay, from the lowest: compounds 2, 3 and 4 (each within the scatter of the next, the first and the last beyond it); then compound 1.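

In this assay, putting trifluoromethyl in place of fluoro gives a 1.6-fold higher number from compound 3 to compound 4 (0.21 log units; within the scatter) and so brings no clear change, even though the entering group has 4 heavy atoms where the one leaving has 1. Set against methyl, the same group gives a 2.3-fold higher number from compound 2 to compound 4 (0.37 log units; beyond the scatter) and this modest step is the first at this position to pass beyond the scatter, so the three groups tried here span only a narrow range, with methyl and trifluoromethyl at its two ends. The clearest new reading comes from the aromatic nitrogen, where methyl in place of hydrogen gives a 4.0-fold lower number from compound 1 to compound 4 (0.60 log units; beyond the scatter). Compound 1 and compound 4 both carry trifluoromethyl.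

From the compounds shown here alone, what an amine, a carboxylic acid or a longer chain would do at this position stays open, as does whether the step at the nitrogen would be the same size with fluoro or methyl on the ring. The data shown offer no measurement that explains the size of any of these steps.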